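From Aryl to Cyclopropylmethyl on an Aromatic Nitrogen

The source may hold more compounds than are shown below. What is called first, only, known or untested is meant among the compounds shown, and "the series" means these compounds.

Compound 1, `O=C(Nc1ccc(F)c(S(=O)(=O)N2CCOCC2)c1)c1cnn(-c2ccccc2)c1`: 8300 nM
Compound 2, `Cc1ccc(-c2nn(-c3ccc(F)cc3)cc2C(=O)Nc2ccc(C)c(S(=O)(=O)N3CCOCC3)c2)cc1`: 24.3 nM
Compound 3, `Cc1ccc(-c2nn(-c3ccc(Cl)cc3Cl)cc2C(=O)Nc2ccc(C)c(S(=O)(=O)N3CCOCC3)c2)cc1`: 14.1 nM

All three compounds were tested in an assay on isolated protein for antagonist activity at Bile acid receptor (Homo sapiens), read by TR-FRET, with a stated time of 20 min; on this read-out higher numbers stand for weaker inhibition and lower numbers for stronger inhibition. Compound 3 has the lowest number shown, though its gap to compound 2 is within the scatter, so the two cannot be told apart; compound 1 lies far behind both. Compound 4, `Cc1ccc(-c2nn(CC3CC3)cc2C(=O)Nc2ccc(C)c(S(=O)(=O)N3CCOCC3)c2)cc1`, has not yet been measured. It differs from compound 3 in one place: cyclopropylmethyl in place of 2,4-dichlorophenyl on an aromatic nitrogen. Among the compounds with values here, only one measured step touches the same position: a 1.7-fold lower number from compound 2 to compound 3 (0.24 log units; within the scatter), which exchanged one six-membered aromatic ring of carbon only for another and stayed within the scatter. That step shows two aromatic groups giving similar numbers here, but it says nothing about a non-aromatic group. Compound 1 carries yet another group at this nitrogen and is far weaker, yet it also differs elsewhere in the shared core, so its value cannot be tied to this position alone. With no direct measured guide for an aromatic-to-alkyl exchange, a moderate rise in the number is expected, a 4.3-fold higher number from compound 3 to compound 4 (0.63 log units; beyond the scatter), with a wide range around it. Compound 4 is therefore estimated at 60 nM, between 15 nM and 300 nM.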

Compound 4, half-maximal inhibitory concentration: 76.9 nM
Estimate against measurement, compound 4: 1.3-fold (0.11 log units) below, and the stated range covers the measured number.
By their numbers in this assay, from the lowest: compounds 3 and 2 (each within the scatter of the next); then compound 4; then compound 1.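

In this assay, exchanging an aromatic ring on this nitrogen for cyclopropylmethyl gives a change that can be read: replacing 2,4-dichlorophenyl gives a 5.5-fold higher number from compound 3 to compound 4 (0.74 log units; beyond the scatter), and replacing 4-fluorophenyl gives a 3.2-fold higher number from compound 2 to compound 4 (0.50 log units; beyond the scatter). Within the data shown here, the earlier exchange of one aromatic ring for another stayed within the scatter, so these are the first steps at this position to show that the group there affects the number, and both are modest, with compound 4 still at 76.9 nM, so an aromatic ring at this position is not essential for inhibition in the nanomolar range. Nothing among the data shown accounts for the rise.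

From the compounds shown here alone, these steps change two things at once, removing the aromatic ring and reducing the number of heavy atoms, so the contribution of each remains open. A benzyl group would keep an aromatic ring while adding a carbon link to the nitrogen, a cyclohexyl group would offer a larger non-aromatic ring, and a chain ending in an amine would test a group of a different kind at the same position.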